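Swapping the Aryl Group on the Hydrazone Carbon

The source may report more compounds than this note shows. Statements on the series, on what has been measured and on what is new or still open speak of the compounds shown alone.

Compound 1 `CN(C)CCn1cnnc1-c1cc(Oc2ccc(NC(=O)N/N=C/c3c(Cl)cccc3Cl)cc2F)ccn1`: 1410 nM
Compound 2 `CN(C)CCn1cnnc1-c1cc(Oc2ccc(NC(=O)N/N=C/c3ccc(F)cc3F)cc2F)ccn1`: 1870 nM
Compound 3 `CN(C)CCn1cnnc1-c1cc(Oc2ccc(NC(=O)N/N=C/c3ccc(O)c(O)c3)cc2F)ccn1`: > 100000 nM (a limit of the assay, not a number)

In a functional assay on A549 cells (Homo sapiens) for cytotoxicity, read by MTT assay, with a stated time of 72 h (a higher number here means a weaker inhibitor, a lower number a stronger inhibitor), compound 1 gives 1410 nM, the lowest of the two numbers shown. Compound 2 is close: a 1.3-fold higher number from compound 1 to compound 2 (0.12 log units; within the scatter). Compound 3 reaches only a limit, > 100000 nM. Among the compounds with values here, that change is the one large step here: an at least 70-fold higher number from compound 1 to compound 3 (1.85 log units; beyond the scatter).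

Compound 4 `CN(C)CCn1cnnc1-c1cc(Oc2ccc(NC(=O)N/N=C/c3cccc(Br)c3)cc2F)ccn1` is not yet measured. It differs from compound 1 in one place: 3-bromophenyl in place of 2,6-dichlorophenyl on a carbon with a double bond to nitrogen. Compound 4 keeps a halogen-bearing phenyl like compounds 1 and 2 rather than the 3,4-dihydroxyphenyl of compound 3, so a step of no more than the scatter is expected, a 1.3-fold higher number from compound 1 to compound 4 (0.11 log units; within the scatter). Compound 4 is therefore estimated at 1800 nM in this assay, within 700 nM to 5000 nM.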

Compound 4, half-maximal inhibitory concentration: 970 nM
The estimate for compound 4 lay 1.9-fold (0.27 log units) above the measured number; measured number inside the range.
By their numbers in this assay, from the lowest: compounds 4, 1 and 2 (each within the scatter of the next). At a limit, above all of these: compound 3.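

Replacing either halogen pair with 3-bromophenyl on this carbon leaves the number within the scatter (a 1.5-fold lower number from compound 1 to compound 4 (0.16 log units; within the scatter) and a 1.9-fold lower number from compound 2 to compound 4 (0.29 log units; within the scatter)), so one bromine serves here as well as two halogens. Compound 3 stands at a limit, not a number. The large gap also appears against this bromine-bearing ring (an at least 100-fold lower number from compound 3 to compound 4 (2.01 log units; beyond the scatter)), so among these four compounds it goes only with 3,4-dihydroxyphenyl.

On these data alone, whether a single hydroxyl on the phenyl is enough for that loss stays open. So does whether an amine or a carboxylic acid there would follow the halogens or the hydroxyl groups.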